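The source may report more compounds than this note shows. Statements on the series, on what has been measured and on what is new or still open speak of the compounds shown alone.

Compound 1 `COc1ccc(-c2cnc3nc(N)nc(N4CCN(C(=O)COc5ccccc5)CC4)c3n2)cc1OC` has the lowest of the two numbers seen in a functional assay on cells (T-cell, Homo sapiens) for inhibition; a lower number here means a stronger inhibitor, a higher number a weaker inhibitor: compound 1 gives 4 nM there. Compound 2 `COc1ccc(-c2cnc3nc(N)nc(OC(C)C)c3n2)cc1OC` gives 400 nM in this assay, a gap from compound 1 that lies beyond the scatter. Compound 3 `CCOc1nc(N)nc2ncc(-c3ccc(C#N)cc3)nc12` sits at the limit of > 10000 nM in this assay, at which 1 of the 3 values shown sits, so compound 3 gives > 10000 nM, which is a limit of the assay rather than a number. Compound 4 `COc1ccc(-c2cnc3nc(N)nc(N4CCN(C(=O)Nc5ccc(F)cc5)CC4)c3n2)cc1OC` is not yet measured; it differs from compound 1 by (4-fluorophenyl)amino in place of phenoxymethyl on a carbonyl carbon. For the measured compounds named here, no measured pair shows what this change does, so the expectation rests on compound 1 alone. The step from compound 1 to compound 4 is expected to stay within the scatter, with no clear direction: a 1.5-fold higher number from compound 1 to compound 4 (0.18 log units; within the scatter). Compound 4 is expected to give 6 nM in this assay, between 1.5 nM and 25 nM.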

Compound 4, half-maximal inhibitory concentration: 7 nM
The estimate for compound 4 lay 1.2-fold (0.07 log units) below the measured number; low and high end bracket the measured number.
By their numbers in this assay, from the lowest: compounds 1 and 4 (each within the scatter of the next); then compound 2. At a limit, above all of these: compound 3.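

In this assay, the step to (4-fluorophenyl)amino is a 1.8-fold higher number from compound 1 to compound 4 (0.24 log units; within the scatter), so on this carbonyl carbon the two groups cannot be told apart. The entering group brings a nitrogen with its hydrogen-bond donor and a fluorine, and it loses the oxygen of phenoxymethyl, yet the number stays within the scatter. Nothing measured here explains this tolerance.

Going by these compounds, what the fluorine and the amide hydrogen each contribute remains open. So does whether a much smaller group on the same carbonyl carbon, such as methyl or dimethylamino, would keep the number.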